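Replacing the methoxy group of compound 1 with hydrogen

The source may report more compounds than this note shows. Statements on the series, on what has been measured and on what is new or still open speak of the compounds shown alone.

In a functional assay on NCI-H460 cells (Homo sapiens) for inhibition, read by sulforhodamine B assay, with a stated time of 48 h, tested at 10 uM (a higher number here means more inhibition of growth at the concentration tested, a lower number less inhibition of growth), compound 1 (`COc1ccc(-c2nc3sc(-c4ccccc4)cn3n2)cc1`) gives 65% and holds the higher of the two numbers available. Compound 2 (`COc1cc(-c2nc3sc(-c4ccccc4)cn3n2)cc(OC)c1OC`) gives 18% and the gap between them lies beyond the scatter. Compound 3 (`c1ccc(-c2nc3sc(-c4ccccc4)cn3n2)cc1`) has not yet been measured. It carries hydrogen in place of methoxy on an aromatic carbon, para to a large group (hydrogen in place of methoxy on an aromatic carbon). Among the measured compounds shown here, no measured pair isolates this change, so the two values alone do not fix its size. Since compound 1 stands at 65% as the higher of the pair, a fall is judged likelier than a rise, although a result within the scatter cannot be excluded. The expected step is a moderate fall, estimated as a number 20 percentage points lower from compound 1 to compound 3 (beyond the scatter) and uncertain in size. Compound 3 is estimated at 45% in this assay (expected range 20% to 70%).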

Compound 3, percent growth inhibition at one concentration: 6%
Compound 3: middle estimate off by 39 percentage points, on the high side, outside the stated range (below it).
By their numbers in this assay, from the lowest: compound 3; then compound 2; then compound 1.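

Hydrogen in place of methoxy on an aromatic carbon, para to a large group, gives a number 59 percentage points lower from compound 1 to compound 3 (beyond the scatter) in this assay, the first step in the series that isolates a single change. The methoxy group at this position therefore accounts for most of the growth inhibition of compound 1, while the core without it, in compound 3, retains only 6%. Nothing measured on these compounds explains the size of this step.

Going by these compounds, whether another group at this position, such as a hydroxyl, an ethoxy group or an amine, would keep the inhibition of compound 1 remains open. Among the compounds shown here, no single-change step connects compound 2 to the other compounds, so the effect of its further methoxy groups cannot be read.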